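Replacing Methyl by Amino: Expected Cytotoxicity of Compound 3

This account rests on a few compounds, and the source may have more. Where it says the series, first, only, none or still open, it means among the compounds named here.

Compound 1, `O=C(/C=C/c1ccc2c(c1)B(O)OC2)c1cccc(F)c1`, in an ADME assay on L929 cells (Mus musculus) for cytotoxicity, read by resazurin assay, with a stated time of 72 h (a higher number here means a weaker inhibitor, a lower number a stronger inhibitor), gives > 10 ug/mL, which is a limit of the assay and not a number.
Compound 2, `Cc1cccc(C(=O)/C=C/c2ccc3c(c2)B(O)OC3)c1`, in this assay gives 8.56 ug/mL.

Compound 2 holds the only number shown; the other value is the limit of > 10 ug/mL in this assay, at which 1 of the 2 values shown sits. Compound 3, `Nc1ccc(C(=O)/C=C/c2ccc3c(c2)B(O)OC3)cc1`, is yet to be measured in this assay. Its change from compound 2 is 4-aminophenyl in place of 3-methylphenyl on a carbonyl carbon.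

Among the measured compounds shown here, one measured step touches the same ring: an at least 1.1-fold lower number from compound 1 to compound 2 (0.06 log units; that floor lies within the scatter), a change that stays within the scatter. The change to compound 3 also alters that ring, so no step beyond the scatter is expected in this assay, in either direction. Compound 3 is therefore estimated at 9 ug/mL, in the range 4 ug/mL to 20 ug/mL. That estimate corresponds to an expected step of a 1.1-fold higher number from compound 2 to compound 3 (0.02 log units; within the scatter).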

Compound 3, half-maximal inhibitory concentration: > 10 ug/mL
Compound 3: no number, only a limit (the forecaster's own chance of this, stated with the estimate: 40%); middle value at least 1.1-fold (0.04 log units) from the limit.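

Taking 4-aminophenyl in place of 3-methylphenyl on a carbonyl carbon gives, in this assay, an at least 1.1-fold higher number from compound 2 to compound 3 (0.06 log units; that floor lies within the scatter). The value of compound 3 is a limit and not a number, so this change can be read only by its floor, and the steps that join compound 1 and compound 3 cannot be read at all. Compound 2 remains the only compound with a number, and the series now rests mostly on a limit: the limit of > 10 ug/mL in this assay, at which 2 of the 3 values shown sit.

The compounds shown leave open whether any group on this ring gives a number clearly apart from that of compound 2, and how large the step to compound 3 really is. Also open, from the compounds shown here alone, is how a carboxylic acid or a longer chain in place of the amine would read in this assay.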